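Swapping the Aryl Amide Cap for a Thiazole

The compounds below may be only part of what the source reports. "The series", "measured", "known", "first", "only" and "open" are said of these compounds alone.

Compound 2 `CC(=O)Nc1cccc2c(-c3cccc(NC(=O)c4ccc(Br)c(C)c4)c3)ccnc12` was tested in a functional assay on A375P cells (Homo sapiens) for antiproliferative activity, read by MTT assay, with a stated time of 48 h; a lower number here means a stronger inhibitor, a higher number a weaker inhibitor. In this assay compound 2 gives > 20000 nM, which is the limit of > 20000 nM in this assay, at which 1 of the 2 values shown sits, and not a measured number. Its parent, compound 1 `Cc1cc(C(=O)Nc2cccc(-c3ccnc4c(N)cccc34)c2)ccc1Br`, gives 9900 nM in this assay, and the step of an at least 2.0-fold higher number from compound 1 to compound 2 (0.30 log units; that floor lies within the scatter) comes with acetyl in place of hydrogen on a nitrogen on an aromatic ring. Compound 3 `CC(=O)Nc1cccc2c(-c3cccc(NC(=O)c4nccs4)c3)ccnc12` differs from compound 2 by 1,3-thiazol-2-yl in place of 4-bromo-3-methylphenyl on a carbonyl carbon. For the measured compounds named here, no measured step touches this kind of change, and the expectation rests on compound 2 alone. The step of a number no higher from compound 2 to compound 3 (the limit leaves the size open) is therefore expected, with compound 3 staying near the limit. Compound 3 is estimated at 20000 nM, between 7000 nM and 60000 nM.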

Compound 3, half-maximal inhibitory concentration: > 20000 nM
Compound 3: a limit, no number (the forecaster's own chance of this, stated with the estimate: 70%); the middle value lies on the limit itself.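

Compound 2 and compound 3 each give only a limit, not a number, so no step between them can be read: the limit of > 20000 nM in this assay, at which 2 of the 3 values shown sit.

From the compounds shown here alone, whether 1,3-thiazol-2-yl or 4-bromo-3-methylphenyl on the carbonyl carbon gives the stronger inhibitor stays open.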